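This account rests on a few compounds, and the source may have more. Where it says the series, first, only, none or still open, it means among the compounds named here.

Measured compounds:
compound 1, `COc1cc(Nc2nc3ccccc3nc2S(=O)(=O)c2ccccc2)cc(OC)c1`, 140 nM in a functional assay on PC-3 cells (Homo sapiens) for cytotoxicity, read by MTT assay, with a stated time of 72 h; on this read-out lower numbers stand for stronger inhibition and higher numbers for weaker inhibition
compound 2, `COc1ccc(S(=O)(=O)c2nc3ccccc3nc2Nc2ccc(C(F)(F)F)cc2)cc1`, 330 nM
compound 3, `COc1cc(Nc2nc3ccccc3nc2S(=O)(=O)c2ccc(Br)cc2)cc(OC)c1`, 18200 nM

Compound 3 gives the highest number of the three in this assay, and its nearest neighbour is compound 2, while compound 1 stands furthest from it. The one step among these compounds that changes a single place is a 130-fold higher number from compound 1 to compound 3 (2.11 log units; beyond the scatter), which is large and lies beyond the scatter.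

Compound 4, `O=S(=O)(c1ccc(Br)cc1)c1nc2ccccc2nc1Nc1ccc(C(F)(F)F)cc1`, has not been measured in this assay. It differs from compound 3 by 4-(trifluoromethyl)phenyl in place of 3,5-dimethoxyphenyl on a nitrogen on an aromatic ring. Among the compounds with values here, no pair of measured compounds changes exactly this place, so no step describes it directly. Compound 2, which carries the same 4-(trifluoromethyl)phenyl group, gives 330 nM, while compound 1 with the 3,5-dimethoxyphenyl group gives 140 nM; these two compounds also differ elsewhere, so they can only hint that the entering group is tolerated. Compound 4 keeps the bromo of compound 3, so the number is expected to stay high, with a moderate step downward as a 3.0-fold lower number from compound 3 to compound 4 (0.48 log units; beyond the scatter). Compound 4 is therefore estimated at 6000 nM, within a range from 1200 nM to 30000 nM.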

Compound 4, half-maximal inhibitory concentration: 4150 nM
Compound 4: the middle estimate sits 1.4-fold (0.16 log units) above what was measured; the range from low to high includes it.
By their numbers in this assay, from the lowest: compound 1; then compound 2; then compound 4; then compound 3.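

In this assay the group on the nitrogen proves able to move the number even with the bromo kept, since 4-(trifluoromethyl)phenyl in place of 3,5-dimethoxyphenyl gives a 4.4-fold lower number from compound 3 to compound 4 (0.64 log units; beyond the scatter) and that modest change leaves compound 4 well short of recovering what the bromo cost. The bromo also raises the number on this second nitrogen substituent: bromo in place of methoxy gives a 13-fold higher number from compound 2 to compound 4 (1.10 log units; beyond the scatter) and bromo in place of hydrogen with 3,5-dimethoxyphenyl gives a 130-fold higher number from compound 1 to compound 3 (2.11 log units; beyond the scatter) so the high number of compound 3 is not peculiar to its 3,5-dimethoxyphenyl group, and neither bromo step among these compounds goes the other way. No measurement at hand offers a reason for either the modest step or the large one.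

Whether the same exchange on the nitrogen would shift the number in the same direction without the bromo cannot be read, as compound 1 and compound 2 differ in more than that one place. On these data alone, it also remains open how chloro or an amine would fare in the place held by the bromo, and whether any group there would keep the number as low as hydrogen does.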